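This account rests on a few compounds, and the source may have more. Where it says the series, first, only, none or still open, it means among the compounds named here.

Measured so far:
- compound 1, `O=c1nc(SCc2ccccc2)nc(SCc2ccccc2F)[nH]1`: "not determined" (no result reported) in an assay for inhibition of Pro-cathepsin H (Homo sapiens), read by fluorescence, tested at 50 uM; on this read-out higher numbers stand for more inhibition at the one concentration tested (going by the name of the read-out) and lower numbers for less inhibition
- compound 2, `O=c1nc(SCc2ccccc2)nc(SCc2cccc(F)c2)[nH]1`: 4.18% in this assay
- compound 3, `O=c1nc(SCc2ccccc2)nc(SCc2ccc([N+](=O)[O-])cc2)[nH]1`: "not determined" (no result reported) in this assay

All three share the same core, a six-membered heterocycle carrying two benzyl-thio arms, and differ only in what sits on the second benzyl ring. Only compound 2 has a number: in this assay compound 2 gives 4.18%, a reading close to no inhibition at the single concentration tested. Among the measured compounds shown here, for compound 1 and compound 3 no result was reported, so compound 3 stands without a number of its own, and no step between measured compounds can be drawn from these data.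

The next compound, compound 4, `O=c1nc(SCc2ccccc2)nc(SCc2ccc(Cl)cc2)[nH]1`, is compound 3 with one change: chloro in place of nitro on an aromatic carbon. For the measured compounds named here, since compound 3 has no value, the step to compound 4 cannot be sized from a measured pair; the only anchor is compound 2, whose 4.18% lies within the usual scatter of zero. On that basis a weak reading is expected for compound 4, with no step beyond the scatter foreseen. The estimate for compound 4 in this assay is 5%, expected to fall between 0% and 20%.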

Compound 4, a percentage reported as inhibition, at one concentration (the size of the read-out at that concentration, not a potency): 6.91%
Compound 4: the middle estimate sits 1.9 percentage points below what was measured, within the range that was stated.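

In this assay, putting 4-chlorophenyl in place of 3-fluorophenyl on a saturated chain carbon bound to a sulfur gives a number 2.7 percentage points higher from compound 2 to compound 4 (within the scatter), so at the one concentration tested these two arms cannot be told apart. This pair changes both the halogen and its place on the ring at once, so even a larger step could not have been assigned to either change alone, and the reading of compound 4 adds a chloro group, para to a large group, to the weak readings without showing any trend. No measurement at hand gives a reason for these readings, or for how the arm relates to the reading.

On these data alone, the step from nitro to chloro cannot be read, as compound 3 has no number of its own, so what the nitro group does at this place stays unknown. Also open, as far as these compounds go, is whether any change to this arm lifts the reading clear of the scatter, for example an amine or a carboxylic acid on the ring, or a longer chain between the ring and the sulfur.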